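Shifting the ring nitrogen: pyridin-2-yl to pyridin-3-yl

The source may report more compounds than this note shows. Statements on the series, on what has been measured and on what is new or still open speak of the compounds shown alone.

Compound 1 `C=CC(=O)NCc1coc(-c2c(N)ncnc2Nc2ccc(Oc3cccc(F)c3)c(Cl)c2)n1`: in an in vitro ADME assay on microsomes from liver (Homo sapiens) for metabolic stability, tested at 5 uM (on this read-out higher numbers stand for a longer-lived compound and lower numbers for a shorter-lived compound), compound 1 gives > 1.66 h, which is a limit of the assay rather than a number.
Compound 2 `C=CC(=O)NCc1coc(-c2c(N)ncnc2Nc2ccc(Oc3ccccn3)c(Cl)c2)n1`: compound 2 gives 0.65 h.

Compound 2 therefore holds the only actual number shown, since the value of compound 1 is a limit (the limit of > 1.66 h in this assay, at which 1 of the 2 values shown sits). Going by the values given here, the single measured step, an at least 2.5-fold lower number from compound 1 to compound 2 (0.40 log units; beyond the scatter), swaps a different group than the one now in question. Compound 3 `C=CC(=O)NCc1coc(-c2c(N)ncnc2Nc2ccc(Oc3cccnc3)c(Cl)c2)n1` differs from compound 2 by pyridin-3-yl in place of pyridin-2-yl on an oxygen on an aromatic ring. Among the compounds with values here, no measured step bears directly on moving the nitrogen within the same ring, and no change beyond the scatter is expected. Compound 3 is estimated at 0.7 h, with a range from 0.3 h to 1.6 h. That estimate means a step of a 1.1-fold higher number from compound 2 to compound 3 (0.03 log units; within the scatter).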

Compound 3, half-life: 0.25 h
The estimate for compound 3 lay 2.8-fold (0.45 log units) above the measured number; the measured number lies below the stated range.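

Moving the ring nitrogen matters at this position: in this assay, pyridin-3-yl in place of pyridin-2-yl gives a 2.6-fold lower number from compound 2 to compound 3 (0.41 log units; beyond the scatter). The two rings have the same atoms and the same counts, so the place of the nitrogen alone separates them, and replacing 3-fluorophenyl with pyridin-3-yl gives an at least 6.6-fold lower number from compound 1 to compound 3 (0.82 log units; beyond the scatter). The value of compound 1 is a limit of the assay, not a number: the limit of > 1.66 h in this assay, at which 1 of the 3 values shown sits.

The compounds shown leave open how pyridin-4-yl on the same oxygen would behave. They also do not show why moving the nitrogen changes the half-life.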